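From methoxymethyl to ethynyl: a step not yet measured

The source may hold more compounds than are shown below. What is called first, only, known or untested is meant among the compounds shown, and "the series" means these compounds.

Compound 1 (`COCC(=O)N(Cc1ccc(OC)c(O)c1)c1cc(OC)c(OC)c(OC)c1`) gives 230 nM 
Compound 2 (`C/C=C/C(=O)N(Cc1ccc(OC)c(N)c1)c1cc(OC)c(OC)c(OC)c1`) gives 300 nM 

Both numbers come from a functional assay on HCT-116 cells (Homo sapiens) for inhibition, read by MTT assay, with a stated time of 48 h (a lower number here means a stronger inhibitor, a higher number a weaker inhibitor), where compound 1 stands level with compound 2, since their two values lie within the scatter of each other. Attention now turns to compound 3 (`C#CC(=O)N(Cc1ccc(OC)c(O)c1)c1cc(OC)c(OC)c(OC)c1`), which has not yet been measured. Its difference from compound 1 is ethynyl in place of methoxymethyl on a carbonyl carbon. Among the compounds with values here, no measured pair in this small set shows what such an exchange does, so the expectation rests only on compound 1 at 230 nM and carries a wide margin. In this assay no step beyond the scatter is expected, and the estimated change is a 1.3-fold lower number from compound 1 to compound 3 (0.11 log units; within the scatter) in the absence of any firmer guide. Compound 3 is estimated at 180 nM, with 40 nM to 800 nM as its expected range.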

Compound 3, half-maximal inhibitory concentration: 310 nM
Beside the measured number, compound 3's estimate is 1.7-fold (0.24 log units) below it, and the stated range covers the measured number.
By their numbers in this assay, from the lowest: compounds 1, 2 and 3 (each within the scatter of the next).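

In this assay, within the data shown here, the exchange of methoxymethyl for ethynyl on a carbonyl carbon gives a 1.3-fold higher number from compound 1 to compound 3 (0.13 log units; within the scatter) and so provides the first direct reading of this change, since compound 1 and compound 2 differ in more than one place. The step shows that, with the rest of the structure held constant, this position takes ethynyl in place of methoxymethyl, including the loss of the oxygen of that group, without a change beyond the scatter. No measurement is available that accounts for this result.

From the compounds shown here alone, whether a longer chain, an amine or a carboxylic acid on this carbonyl carbon would move the number beyond the scatter remains open. The compounds shown also leave open whether ethynyl would read the same way if the rest of the core of compound 1 were altered.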